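Removing the methylselanyl group from compound 3

The compounds below may be only part of what the source reports. "The series", "measured", "known", "first", "only" and "open" are said of these compounds alone.

In a functional assay on CCRF-CEM cells (Homo sapiens) for cytotoxicity, read by MTT assay, with a stated time of 72 h (a higher number here means that more compound is tolerated, a lower number that less compound is tolerated), compound 1 `CSc1ccc(CNc2nc(SC)nc3ncccc23)cc1` gives 59000 nM, a value close to the edge of what the assay can report. Compound 2 `CCCCCSc1nc(NCc2ccc([Se]C)cc2)c2ccccc2n1` reaches only the limit of > 100000 nM in this assay, not a number. Compound 3 `CSc1nc(NCc2ccc([Se]C)cc2)c2ccccc2n1` likewise stops at the limit of > 100000 nM in this assay. The change a step that the two limits leave unreadable from compound 2 to compound 3 therefore cannot be read, because both ends sit at the limit of > 100000 nM in this assay, at which 2 of the 3 values shown sit. Compound 3 thus stands at the top of what this assay can show, together with compound 2, while compound 1 sits a little lower on a different core.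

Compound 4 `CSc1nc(NCc2ccccc2)c2ccccc2n1` differs from compound 3 by a hydrogen atom in place of a group of 2 heavy atoms (1 carbon, 1 selenium; no ring), on an aromatic carbon. Going by the values given here, no measured step in this set touches this group, so nothing among the measured changes bears directly on it. Since compound 3 already sits at the limit > 100000 nM in this assay, and since the one readable change among these compounds cannot be read, the expectation is a step of a number no higher from compound 3 to compound 4 (the limit leaves the size open) that stays within the scatter. Compound 4 is therefore estimated to give 100000 nM in this assay, within a range from 30000 nM to 300000 nM, most likely again only as a limit.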

Compound 4, concentration lethal to 50% of the cells: > 100000 nM
Compound 4: only a limit was reported (the forecaster's own chance of this, stated with the estimate: 60%); the middle value sits exactly at the limit.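

Compound 3 and compound 4 both stop at a limit of the assay rather than at a number, so the step between them cannot be read: the limit of > 100000 nM in this assay, at which 3 of the 4 values shown sit.

The compounds shown leave open whether swapping the methylselanyl group for hydrogen changes the outcome at all in this assay.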